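The compounds below may be only part of what the source reports. "The series", "measured", "known", "first", "only" and "open" are said of these compounds alone.

In a functional assay on cells (Homo sapiens) for antiproliferative activity, read by MTT assay, with a stated time of 48 h (on this read-out higher numbers stand for weaker inhibition and lower numbers for stronger inhibition), compound 3 `CN(C)CCCn1c(N)c(-c2nc3ccccc3[nH]2)c2nc(C#N)c(C#N)nc21` gives 1820 nM, the lowest of the numbers shown. Compound 1 `CCN(CC)CCn1c(N)c(-c2nc3ccccc3[nH]2)c2nc(C#N)c(C#N)nc21` gives 25400 nM. Compound 2 `N#Cc1nc2c(-c3nc4ccccc4[nH]3)c(N)n(CCN3CCCC3)c2nc1C#N` gives only a limit, > 50000 nM, and not a number.

Compound 4 `N#Cc1nc2c(-c3nc4ccccc4[nH]3)c(N)n(CCCN3CCCCC3)c2nc1C#N` differs from compound 3 in the group at the end of the chain: piperidin-1-yl in place of dimethylamino on a saturated chain carbon, three bonds along the chain from an aromatic nitrogen. Piperidin-1-yl stands in place of dimethylamino on a saturated chain carbon, three bonds along the chain from an aromatic nitrogen.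

Going by the values given here, no measured step makes this exact change. As far as these compounds go, the closest in kind is an at least 1.9-fold higher number from compound 1 to compound 2 (0.29 log units; that floor lies within the scatter), where a ring amine, pyrrolidin-1-yl, replaces the open diethylamino group, but this is only a floor and the true size remains open. The large steps of a 14-fold lower number from compound 1 to compound 3 (1.14 log units; beyond the scatter) and an at least 27-fold lower number from compound 2 to compound 3 (1.43 log units; beyond the scatter) change the chain and the amine together, so they cannot separate the two. Compound 4 keeps the longer chain of compound 3 but gives up its dimethylamino group, and so part of that gain may be kept and part lost. A modest move toward a higher number is therefore expected, as the estimated step of a 2.5-fold higher number from compound 3 to compound 4 (0.39 log units; beyond the scatter). For compound 4 the expected value is 4500 nM, with an estimated range of 1200 nM to 20000 nM.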

Compound 4, half-maximal inhibitory concentration: 6230 nM
For compound 4 the middle estimate is 1.4-fold (0.14 log units) below the measured one; the range from low to high includes it.
By their numbers in this assay, from the lowest: compound 3; then compound 4; then compound 1. At a limit, above all of these: compound 2.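

The exchange of dimethylamino for piperidin-1-yl, on a saturated chain carbon three bonds along the chain from an aromatic nitrogen, is the first change among these compounds that leaves the chain as it is, and in this assay it alone gives a 3.4-fold higher number from compound 3 to compound 4 (0.53 log units; beyond the scatter), a modest cost for the ring amine. Set against the compounds with the shorter chain, the 3-(piperidin-1-yl)propyl group still stands on the better side, with a 4.1-fold lower number from compound 1 to compound 4 (0.61 log units; beyond the scatter) and an at least 8.0-fold lower number from compound 2 to compound 4 (0.90 log units; beyond the scatter), although these two steps change the chain and the amine together. Compound 2 gives a limit and not a number, so the second of these steps is only a floor: the limit of > 50000 nM in this assay, at which 1 of the 4 values shown sits.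

The compounds shown hold no pair that differs in chain length alone, so the share of the chain and the share of the amine in those two steps stay unresolved. As far as these compounds go, how a 3-(pyrrolidin-1-yl)propyl group, a 3-(diethylamino)propyl group, a 2-(dimethylamino)ethyl group or a morpholine ring at the end of the chain would read in this assay also remains open.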